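Amine-nitrogen substituent swaps in one series

The source may report more compounds than this note shows. Statements on the series, on what has been measured and on what is new or still open speak of the compounds shown alone.

compound 1 `CCOC(=O)C1=C(NN=C(C(C)=O)C(C)=O)Nc2[nH]nc(C)c2C1c1ccc(N(C)C)cc1` — 17000 nM
compound 2 `CCOC(=O)C1=C(N/N=C(/Cl)C#N)Nc2[nH]nc(C)c2C1c1ccc(N(C)C)cc1` — 26200 nM
compound 3 `CCOC(=O)C1=C(N/N=C(/C(C)=O)C(=O)OCC)Nc2[nH]nc(C)c2C1c1ccc(N(C)C)cc1` — > 100000 nM (a limit)

In a functional assay on HeLa cells (Homo sapiens) for inhibition, read by MTT assay, with a stated time of 48 h (a higher number here means a weaker inhibitor, a lower number a stronger inhibitor), compound 1 gives 17000 nM and compound 2 gives 26200 nM. For compound 3 the assay reports only a limit, > 100000 nM. Compound 3 thus stands at the weak end of the three: an at least 5.8-fold higher number from compound 1 to compound 3 (0.76 log units; beyond the scatter) and an at least 3.8-fold higher number from compound 2 to compound 3 (0.58 log units; beyond the scatter), both beyond the scatter, whereas a 1.5-fold higher number from compound 1 to compound 2 (0.19 log units; within the scatter). Compound 4 `CCOC(=O)C1=C(N/C=N/c2ccc(C)cc2)Nc2[nH]nc(C)c2C1c1ccc(N(C)C)cc1` differs from compound 3 by a group of 9 heavy atoms (8 carbon, 1 nitrogen; one six-membered aromatic ring of carbon only) in place of a group of 10 heavy atoms (6 carbon, 1 nitrogen, 3 oxygen; no ring), on an amine nitrogen. For the measured compounds named here, both measured steps into compound 3 move toward weaker inhibition as the group of 10 heavy atoms enters on that nitrogen; compound 4 instead carries a group with one aromatic ring there, and no measured step covers such a group. A return toward the range of compound 1 and compound 2 is expected, an at least 3.3-fold lower number from compound 3 to compound 4 (0.52 log units; beyond the scatter). Compound 4 is estimated at 30000 nM, within 8000 nM to 100000 nM, with some chance that the assay again reports only a limit.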

Compound 4, half-maximal inhibitory concentration: 43200 nM
Beside the measured number, compound 4's estimate is 1.4-fold (0.16 log units) below it; low and high end bracket the measured number.
By their numbers in this assay, from the lowest: compounds 1, 2 and 4 (each within the scatter of the next, the first and the last beyond it). At a limit, above all of these: compound 3.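

On this amine nitrogen, a group with one six-membered aromatic ring of carbon only, in place of the ring-free group of 10 heavy atoms, gives an at least 2.3-fold lower number from compound 3 to compound 4 (0.36 log units; beyond the scatter), so a ring there still leaves a measured value in this assay. Compound 3 stays a limit, so that step is only a bound: the limit of > 100000 nM in this assay, at which 1 of the 4 values shown sits. The ring brings no gain over the two smaller ring-free groups: a 1.6-fold higher number from compound 2 to compound 4 (0.22 log units; within the scatter), and a 2.5-fold higher number from compound 1 to compound 4 (0.41 log units; beyond the scatter).

Still open, as far as these compounds go, is how an amine, a carboxylic acid or a longer chain on this nitrogen would read.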